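A Longer Dimethylamino Chain on the Shared Core

The source may report more compounds than this note shows. Statements on the series, on what has been measured and on what is new or still open speak of the compounds shown alone.

In a functional assay (trachea) with Cavia porcellus as the target (a lower number here means that less compound is needed, a higher number that more compound is needed for the effect), compound 1 `C=CCCn1c(=O)c2[nH]cnc2n(CCC)c1=O` gives 200 nM and compound 2 `CCCn1c(=O)n(CCN(C)C)c(=O)c2[nH]cnc21` gives 2700 nM as the higher of the two numbers. The step of a 14-fold higher number from compound 1 to compound 2 (1.13 log units; beyond the scatter) is large and comes with dimethylamino in place of vinyl on a saturated chain carbon, two bonds along the chain from an aromatic nitrogen. Compound 3 `CCCn1c(=O)n(CCCN(C)C)c(=O)c2[nH]cnc21` changes that same place, with (dimethylamino)methyl in place of dimethylamino, and the change (dimethylamino)methyl in place of dimethylamino on a saturated chain carbon, two bonds along the chain from an aromatic nitrogen turns 2-(dimethylamino)ethyl into 3-(dimethylamino)propyl. Among the measured compounds shown here, the only measured step swapped vinyl for dimethylamino, whereas compound 3 keeps the dimethylamino group of compound 2 at a longer reach, so that step says little about this one. In this assay the expected step of a 1.4-fold lower number from compound 2 to compound 3 (0.13 log units; within the scatter) is slightly downward and within the scatter. Compound 3 is estimated at 2000 nM with a range from 600 nM to 6500 nM as the expected span.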

Compound 3, half-maximal effective concentration: 20500 nM
The estimate for compound 3 lay 10-fold (1.01 log units) below the measured number; measured number outside the range, above it.
By their numbers in this assay, from the lowest: compound 1; then compound 2; then compound 3.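

In this assay the position proves sensitive to the length of the chain as well as to the group it carries: going from 2-(dimethylamino)ethyl to 3-(dimethylamino)propyl, with the dimethylamino group kept, gives a 7.6-fold higher number from compound 2 to compound 3 (0.88 log units; beyond the scatter) and is thus no neutral extension. Measured against the vinyl-bearing chain, the two changes add up to a 100-fold higher number from compound 1 to compound 3 (2.01 log units; beyond the scatter) and leave 3-(dimethylamino)propyl with the highest number of the three. No evidence is available to explain this rise.

With only two lengths of the amine chain in hand, the compounds shown leave open whether a still longer chain ending in dimethylamino would raise the number further. They also leave open whether the rise depends on the dimethylamino group itself, which a chain ending in a hydroxyl group or a carboxylic acid could test.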